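The source may hold more compounds than are shown below. What is called first, only, known or untested is meant among the compounds shown, and "the series" means these compounds.

In a functional assay on the whole organism for antagonist activity, with Mus musculus as the target (a lower number here means that less compound is needed, a higher number that more compound is needed for the effect), compound 1 `CC(=O)N(C)C(C)C#CCn1cncc1C` gives 3.7 mg/kg, while compound 2 `CC1CCC(=O)N1CC#CCn1ccnc1` gives 1.1 mg/kg. Compound 2 therefore has the lower number of the two, meaning that less of it is needed for the effect, and its gap to compound 1 lies beyond the usual scatter of repeated measurements.

Compound 3 `Cc1cncn1CC#CCN1C(=O)CCC1C` is built from compound 2 by a single small edit: methyl in place of hydrogen on an aromatic carbon. In short, a methyl takes the place of a hydrogen on an aromatic carbon of the five-membered aromatic ring with 2 nitrogen.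

Within the data shown here, no measured pair shows this change on its own, so any forecast in this assay is loose and rests on very few data. The expectation is a moderate rise in the number, taking it towards the level of compound 1 at 3.7 mg/kg, though a step lost within the scatter would be no surprise. The expected size of the change is a 2.0-fold higher number from compound 2 to compound 3 (0.30 log units; within the scatter). For compound 3 the estimated dose is 2.2 mg/kg, with an expected range from 0.6 mg/kg to 8 mg/kg.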

Compound 3, dose for half-maximal effect: 1.4 mg/kg
Compound 3: the middle estimate sits 1.6-fold (0.20 log units) above what was measured; measured number inside the range.
By their numbers in this assay, from the lowest: compounds 2 and 3 (each within the scatter of the next); then compound 1.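

In this assay, among these compounds, placing a methyl in place of a hydrogen on an aromatic carbon of the five-membered aromatic ring with 2 nitrogen gives a 1.3-fold higher number from compound 2 to compound 3 (0.10 log units; within the scatter), and this pair is the first direct view of that change on its own. At this position, next to the ring nitrogen and next to the ring atom that bears a large group, the added methyl leaves the dose needed in the whole animal indistinguishable from that of the parent compound, at least in this single pair. Nothing available explains this outcome, and no other kind of measurement bears on it.

Whether this position would accept more than a single carbon remains open, since the compounds shown do not include an ethyl, a chlorine atom, a methoxy group or an aminomethyl group there. One pair also cannot tell whether a methyl would give a similarly small step on the other aromatic carbons of this ring, or whether this result would hold if the rest of the molecule were changed.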